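Three Limits and a Fourth Compound Expected to Follow

The source may hold more compounds than are shown below. What is called first, only, known or untested is meant among the compounds shown, and "the series" means these compounds.

Compound 1 `Nc1ncn(CCC2(N)OC(=O)C(OCc3ccccc3)=C2OCc2ccccc2)c(=O)n1`, compound 2 `NC1(CCn2c(=O)[nH]c(=O)[nH]c2=O)OC(=O)C(OCc2ccccc2)=C1OCc1ccccc1` and compound 3 `O=C1O[C@H]([C@@H](O)Cn2c(=O)[nH]c(=O)[nH]c2=O)C(OCc2ccccc2)=C1OCc1ccccc1` were all tested for growth inhibition of a pancreatic tumour cell line. In a functional assay on MIA PaCa-2 cells (Homo sapiens) for inhibition, read by MTT assay, with a stated time of 72 h (on this read-out higher numbers stand for weaker inhibition and lower numbers for stronger inhibition), compound 1 gives only a limit, > 100000 nM. In this assay compound 2 likewise gives only a limit, > 100000 nM. Compound 3 also gives only a limit in this assay, > 100000 nM. The step from compound 2 to compound 1 is a step that the two limits leave unreadable from compound 2 to compound 1; the change it makes is a group of 8 heavy atoms (3 carbon, 4 nitrogen, 1 oxygen; one six-membered aromatic ring with 3 hetero atoms) in place of a group of 9 heavy atoms (3 carbon, 3 nitrogen, 3 oxygen; one six-membered aromatic ring with 3 hetero atoms), on a saturated chain carbon, two bonds along the chain from a saturated ring carbon. The difference between the core of compound 3 and that of compound 2 is not broken down here.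

Compound 4 `Nc1ncn(C[C@H](O)[C@H]2OC(=O)C(OCc3ccccc3)=C2OCc2ccccc2)c(=O)n1` has not yet been measured in this assay. It arises from compound 3 by the same kind of change: a group of 8 heavy atoms (3 carbon, 4 nitrogen, 1 oxygen; one six-membered aromatic ring with 3 hetero atoms) in place of a group of 9 heavy atoms (3 carbon, 3 nitrogen, 3 oxygen; one six-membered aromatic ring with 3 hetero atoms), on a saturated chain carbon, two bonds along the chain from an oxygen on a saturated carbon and a saturated ring carbon. Around the place the two cases differ: in compound 3 the saturated chain carbon is two bonds along the chain from an oxygen on a saturated carbon and a saturated ring carbon, whereas in compound 2 it is two bonds along the chain from a saturated ring carbon.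

Compound 4 is expected to sit at the limit as well, because of the limit of > 100000 nM in this assay, at which 3 of the 3 values shown sit. The step from compound 3 to compound 4 is therefore expected to be a number no higher from compound 3 to compound 4 (the limit leaves the size open), beside the earlier step that the two limits leave unreadable. The estimate for compound 4 is 100000 nM, with a range from 40000 nM to 300000 nM.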

Compound 4, half-maximal inhibitory concentration: 71700 nM
Beside the measured number, compound 4's estimate is 1.4-fold (0.14 log units) above it, and the stated range covers the measured number.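

In this assay, the exchange of one six-membered aromatic ring with 3 hetero atoms for the other, on a saturated chain carbon of the core of compound 3, gives an at least 1.3-fold lower number from compound 3 to compound 4 (0.14 log units; that floor lies within the scatter). On these data alone, this shows that compound 4 returns a measured number on this core, but the printed floor of the step lies within the scatter, so it does not establish a real gain, and its full size stays open. The same exchange on the core of compound 2 cannot be read, so the result is neither confirmed nor contradicted on a second core, and the comparison rests on so little because nearly all the values are limits: the limit of > 100000 nM in this assay, at which 3 of the 4 values shown sit.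

The compounds shown leave open whether this exchange would give a readable step on any further core. They also leave open how a carboxylic acid or a longer chain on that saturated chain carbon would fare in this assay.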